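Swapping a dimethoxyphenyl for a fluorophenyl on a thiazole acid

The source may report more compounds than this note shows. Statements on the series, on what has been measured and on what is new or still open speak of the compounds shown alone.

Compound 1, `COc1ccc(OC)c(-c2nc(C(c3ccccc3)c3ccccc3)sc2CC(=O)O)c1`, carries a 2,5-dimethoxyphenyl on the shared core. In an in vitro assay on HEK385-7 cells for displacement of a labelled ligand from prostaglandin D2 receptor 2 (Homo sapiens) (a lower number here means a stronger inhibitor, a higher number a weaker inhibitor), compound 1 gives only a limit of the assay, > 105 nM, so its true strength is not pinned down (the limit of > 105 nM in this assay, at which 1 of the 2 values shown sits). A second member of the series, compound 2, `O=C(O)Cc1sc(C(c2ccccc2)c2ccc(F)cc2)nc1-c1ccc(Cl)cc1`, gives 17 nM in this assay; no single change links it to compound 1, so its value stands alone as a sign of what this core can reach.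

Compound 3, `O=C(O)Cc1sc(C(c2ccccc2)c2ccccc2)nc1-c1ccc(F)cc1`, has not been measured. It differs from compound 1 in one place: 4-fluorophenyl in place of 2,5-dimethoxyphenyl on an aromatic carbon. With the limit on compound 1, only the direction can be judged from the numbers, and the step from compound 1 to compound 3 is expected to run toward lower numbers by more than the scatter, with compound 2 showing that values in that region occur. The estimated outcome for compound 3 in this assay is 30 nM, expected to fall between 8 nM and 120 nM, a step of an at least 3.5-fold lower number from compound 1 to compound 3 (0.54 log units; beyond the scatter).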

Compound 3, half-maximal inhibitory concentration: 8.7 nM
For compound 3 the middle estimate is 3.4-fold (0.54 log units) above the measured one, and the stated range covers the measured number.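

The step shows that this aromatic carbon, next to the ring nitrogen, is highly sensitive to the group it carries: in this assay, placing 4-fluorophenyl there in place of 2,5-dimethoxyphenyl gives an at least 12-fold lower number from compound 1 to compound 3 (1.08 log units; beyond the scatter). The earlier compounds shown here could not show this, since no single change linked any pair of them. The true size of the step stays unknown and could be larger, because compound 1 gives only a limit of the assay: the limit of > 105 nM in this assay, at which 1 of the 3 values shown sits.

The swap also changes more than one feature at once, as the group that leaves has 10 heavy atoms and 2 hydrogen-bond acceptors, while the group that enters has 7 heavy atoms and 0 hydrogen-bond acceptors. The compounds shown therefore cannot say whether the gain comes from losing the methoxy groups, from gaining the fluorine, or from both. A plain phenyl or a phenyl with a single methoxy group at this carbon would help separate those possibilities, and a phenyl bearing a nitrile would test how far the fluorine can be replaced.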